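Thiadiazole thioether in place of purinyl thioether on the naphthol core

A few compounds are considered here, and "the series" means these few. Any claim that something is new, unique, unknown or untested is made for them only; others in the source may bear on it.

Measured so far:
compound 1 `Cc1nnc(Sc2cc(NC(=O)c3ccc(Cl)cc3)c3ccccc3c2O)s1` in an assay on isolated protein for inhibition of RAC-alpha serine/threonine-protein kinase (Homo sapiens), read by fluorescence, with a stated time of 30 min, tested at 10 uM (a higher number here means more inhibition at the concentration tested (going by the name of the read-out), a lower number less inhibition), gives 8.48%
compound 2 `O=C(Nc1cc(Sc2ncnc3nc[nH]c23)c(O)c2ccccc12)c1ccc(Cl)cc1` in this assay gives 21.7%

Compound 2 stands highest of the two numbers; its nearest neighbour is compound 1, and the step of a number 13.2 percentage points higher from compound 1 to compound 2 (beyond the scatter) lies beyond the scatter. Compound 3 `O=C(Nc1cc(Sc2nncs2)c(O)c2ccccc12)c1ccc(Cl)cc1` is not yet measured. Compared with compound 2 the change is a group of 5 heavy atoms (2 carbon, 2 nitrogen, 1 sulfur; one five-membered aromatic ring with 3 hetero atoms) in place of a group of 9 heavy atoms (5 carbon, 4 nitrogen; one five-membered aromatic ring with 2 hetero atoms, one six-membered aromatic ring with 2 hetero atoms), on a sulfur. Among the compounds with values here, the only measured step that bears on this is a number 13.2 percentage points higher from compound 1 to compound 2 (beyond the scatter), which put the purinyl group onto the same sulfur in place of a group of the same ring type as the one now entering, and raised the read-out modestly. The step to compound 3 runs the other way and is expected to give back most of that gain, so a decrease of the order of a number 11.7 percentage points lower from compound 2 to compound 3 (beyond the scatter) is expected, with the result falling near the level of compound 1. Compound 3 is therefore estimated at 10%, within -2% to 24%.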

Compound 3, a percentage reported as inhibition, at one concentration (the size of the read-out at that concentration, not a potency): 7.5%
Estimate against measurement, compound 3: 2.5 percentage points above; measured number inside the range.
By their numbers in this assay, from the lowest: compounds 3 and 1 (each within the scatter of the next); then compound 2.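

In this assay, replacing the purinyl group on the sulfur with 1,3,4-thiadiazol-2-yl gives a number 14.2 percentage points lower from compound 2 to compound 3 (beyond the scatter), so the higher read-out goes with the purinyl group in a comparison where the thiadiazole carries no methyl. The methyl on the thiadiazole's aromatic carbon makes no difference that can be read, with a number 1 percentage points lower from compound 1 to compound 3 (within the scatter), so that methyl does not account for the gap between the purinyl and thiadiazole compounds. Nothing available explains why the purinyl group gives the higher number.

Open, on these data alone, is whether another group on the sulfur, such as a pyridine or a phenyl ring carrying a carboxylic acid, would take the read-out beyond that of compound 2. Also open, as far as these compounds go, is whether the sulfur itself matters, as an oxygen or a methylene in its place would show.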